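The source may hold more compounds than are shown below. What is called first, only, known or untested is meant among the compounds shown, and "the series" means these compounds.

Measured so far:
- Compound 1 `CCc1cccc2cc(C(=O)O)cnc12`: in a functional assay on the whole organism (strain Sprague-Dawley) for inhibition, with Rattus norvegicus as the target (on this read-out higher numbers stand for an effect only at larger amounts of compound and lower numbers for an effect already at smaller amounts), compound 1 gives > 50 mg/kg, which is a limit of the assay and not a number.
- Compound 2 `Cc1cccc2c(=O)c(-c3nn[nH]n3)c[nH]c12`: in this assay compound 2 gives > 5 mg/kg, again a limit of the assay.
- Compound 3 `Cc1cccc2cc(C(=O)O)cnc12`: in this assay compound 3 gives > 50 mg/kg, also a limit of the assay.

Compound 2 therefore stands only at the limit of > 5 mg/kg in this assay, at which 1 of the 3 values shown sits, while the two other values sit at the limit of > 50 mg/kg in this assay, at which 2 of the 3 values shown sit. No value in this set is a true number, so compound 2 cannot be placed above or below the others. Among the compounds with values here, the single step between measured compounds, a step that the two limits leave unreadable from compound 1 to compound 3, concerns a different change on a different core and gives no readable size.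

Compound 4 `CC(C)Oc1cccc2c(=O)c(-c3nn[nH]n3)c[nH]c12` differs from compound 2 in one place: isopropoxy in place of methyl on an aromatic carbon. Within the data shown here, no measured step bears on this change, and the starting point is itself a limit, so no step beyond the scatter is expected in either direction, and a further limit is the most likely outcome. Compound 4 is estimated at 10 mg/kg, with a range from 2 mg/kg to 50 mg/kg. Written as a step, the expected change is a step that the limit leaves unreadable from compound 2 to compound 4.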

Compound 4, minimum effective dose: 0.078 mg/kg
Beside the measured number, compound 4's estimate is 130-fold (2.11 log units) above it; the whole stated range lies above it.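

In this assay, isopropoxy in place of methyl on this aromatic carbon, ortho to a fused ring and meta to a fused ring, gives an at least 64-fold lower number from compound 2 to compound 4 (1.80 log units; beyond the scatter). Within the data shown here, this is the first step in the set that can be read, and it shows that a change at this one place on the shared core can move the read-out far beyond the scatter. Its true size is fixed from one side only, since the starting point is a limit and not a number: the limit of > 5 mg/kg in this assay, at which 1 of the 4 values shown sits.

No measurement shown gives a cause for this step. On these data alone, whether methoxy, a longer chain such as butoxy, or an amine at the same place would give a similar number remains open, and so does how much of the step depends on the oxygen and how much on the branched chain.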